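Swapping a ring-bound halogen: what to expect for compound 4

The source may hold more compounds than are shown below. What is called first, only, known or untested is meant among the compounds shown, and "the series" means these compounds.

Compound 1, with structure `CC1CC(=O)N(CC(=O)N2CCN(c3ccc(Cl)cc3)CC2)C1=O`, was tested in a functional assay on the whole organism (strain CD1) with Mus musculus as the target, in the maximal electroshock model, with a stated time of 0.5 h (on this read-out lower numbers stand for an effect already at smaller amounts and higher numbers for an effect only at larger amounts of compound), and gave 100 mg/kg. Compound 3, with structure `CCC1(C)CC(=O)N(CC(=O)N2CCN(c3ccccc3Cl)CC2)C1=O`, gave 100 mg/kg, so compound 1 stands level with compound 3 at the digits shown, and together they hold the lowest numbers of the three. Compound 2, with structure `CC1CC(=O)N(CC(=O)N2CCN(c3ccccc3)CC2)C1=O`, gave 300 mg/kg and stands furthest from compound 1.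

Compound 4, with structure `CC1CC(=O)N(CC(=O)N2CCN(c3ccccc3F)CC2)C1=O`, is new. Compared with compound 1, the change is 2-fluorophenyl in place of 4-chlorophenyl on an amine nitrogen in a ring.

Among the measured compounds shown here, only one measured step bears on this change: a 3.0-fold higher number from compound 1 to compound 2 (0.48 log units; beyond the scatter), where removing the chloro from the aromatic carbon raised the number. For the measured compounds named here, compound 4 keeps a halogen on the aromatic ring, so the full loss seen there need not follow, but the halogen is a different one in a different named group, and no measured pair shows that exact swap. Compound 3, which carries a 2-chlorophenyl, matches compound 1 at the digits shown, though its core also differs.

On that basis, only a small shift is expected, of size a 1.5-fold higher number from compound 1 to compound 4 (0.18 log units; within the scatter). Compound 4 is therefore expected to give about 150 mg/kg, with a likely range from 70 mg/kg to 300 mg/kg.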

Compound 4, minimum effective dose: 300 mg/kg
Compound 4: middle estimate off by 2.0-fold (0.30 log units), on the low side; low and high end bracket the measured number.
By their numbers in this assay, from the lowest: compounds 1 and 3 (each within the scatter of the next); then compounds 2 and 4 (each within the scatter of the next).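

In this assay, replacing 4-chlorophenyl with 2-fluorophenyl on the amine nitrogen in the ring gives a 3.0-fold higher number from compound 1 to compound 4 (0.48 log units; beyond the scatter), so not every halogen-bearing phenyl group at this position keeps the number seen with 4-chlorophenyl. Putting fluoro in place of hydrogen on an aromatic carbon gives no change at the digits printed from compound 2 to compound 4 (within the scatter), which places 2-fluorophenyl level with the plain phenyl group on this shared core and shows that having a halogen on the ring is not enough by itself to match the 4-chlorophenyl result. Nothing available explains this difference at the level of mechanism.

The halogen and its place on the ring change together on going to the 2-fluorophenyl group, so the compounds shown cannot say which of the two matters here. A 4-fluorophenyl group on the same core would separate these two changes, and a 4-bromophenyl group would show whether a different halogen in the same place as the chloro gives a similar number.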